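The compounds below may be only part of what the source reports. "The series", "measured", "known", "first", "only" and "open" are said of these compounds alone.

Measured compounds:
- compound 1, `CC(C)(C)c1cc(C(=O)NC2CCN(Cc3ccccc3)CC2)cc(C(C)(C)C)c1O`: 85100 nM
- compound 2, `CC(C)(C)c1cc(/C=C/C(=O)NCC2CCN(Cc3ccccc3)CC2)cc(C(C)(C)C)c1O`: 11700 nM
- compound 3, `CC(C)(C)c1cc(/C=C/C(=O)NCCC2CCN(Cc3ccccc3)CC2)cc(C(C)(C)C)c1O`: 8500 nM

In an assay on isolated protein for inhibition of Amine oxidase [flavin-containing] B (Homo sapiens), read by fluorescence, with stated times of 15 min and 20 min (a higher number here means a weaker inhibitor, a lower number a stronger inhibitor), compound 3 gives 8500 nM. Compound 2 sits within the scatter of compound 3, so no order is drawn between them. Compound 1, in this assay, gives 85100 nM, a gap from compound 3 that lies beyond the scatter. Among the compounds with values here, no step between any two of the measured compounds changes only one place, so no measured single change exists to rest on.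

Compound 4, `CC(C)(C)c1cc(/C=C/C(=O)NCCC2CCN(Cc3cccc(F)c3)CC2)cc(C(C)(C)C)c1O`, differs from compound 3 by fluoro in place of hydrogen on an aromatic carbon. The expected step from compound 3 to compound 4 is a 1.2-fold lower number from compound 3 to compound 4 (0.08 log units; within the scatter), with no direction beyond the scatter expected. For compound 4 the estimate in this assay is 7000 nM, in the range 3000 nM to 18000 nM.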

Compound 4, half-maximal inhibitory concentration: 6500 nM
Beside the measured number, compound 4's estimate is 1.1-fold (0.03 log units) above it, within the range that was stated.
By their numbers in this assay, from the lowest: compounds 4, 3 and 2 (each within the scatter of the next); then compound 1.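

In this assay, within the data shown here, this is the first step that changes only one place: fluoro in place of hydrogen on an aromatic carbon, benzyl to 3-fluorobenzyl, gives a 1.3-fold lower number from compound 3 to compound 4 (0.12 log units; within the scatter). At this position, fluoro therefore cannot be told apart from hydrogen, and no order is drawn between compound 3 and compound 4. Nothing measured here bears on a cause for this result.

Still open, on these data alone, is whether chloro, methoxy or trifluoromethyl at this carbon would separate from hydrogen. Also open, as far as these compounds go, is whether fluoro on another carbon of this ring would do so.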